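This account rests on a few compounds, and the source may have more. Where it says the series, first, only, none or still open, it means among the compounds named here.

Compound 1 `CCc1nc(CC)c(Cc2c[nH]cn2)s1` and compound 2 `CCc1nc(CC)c(C(C)c2c[nH]cn2)s1` share one core; compound 3 `CCc1sc(Cc2c[nH]cn2)nc1C` and compound 4 `CCc1nc(Cc2c[nH]cn2)sc1CC` share another, and the difference between the two cores is not broken down here. In a functional assay on the whole organism (Abdomen) with Mus musculus as the target (a lower number here means that less compound is needed, a higher number that more compound is needed for the effect), compound 1 gives only a limit, > 30 mg/kg. Compound 2 likewise gives only a limit in this assay, > 30 mg/kg. The step that the two limits leave unreadable from compound 1 to compound 2 is not readable because of the limit of > 30 mg/kg in this assay, at which 2 of the 3 values shown sit. That change is methyl in place of hydrogen on a saturated chain carbon bound to two aromatic carbons. Compound 3 gives 2.8 mg/kg in this assay. Compound 4 differs from compound 3 by methyl in place of hydrogen on a saturated chain carbon bound to an aromatic carbon, the same kind of change as from compound 1 to compound 2, but here on a saturated chain carbon bound to an aromatic carbon rather than one bound to two aromatic carbons. With neither end of the earlier step a number, the expected step from compound 3 to compound 4 rests only on the small size of the change: a 1.4-fold higher number from compound 3 to compound 4 (0.15 log units; within the scatter), within the usual scatter. The estimate for compound 4 in this assay is 4 mg/kg, between 1.5 mg/kg and 12 mg/kg.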

Compound 4, dose for half-maximal effect: > 30 mg/kg
Compound 4 gave a limit, no number (the forecaster's own chance of this, stated with the estimate: 10%); middle value at least 7.5-fold (0.87 log units) away from the limit.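

In this assay, methyl in place of hydrogen on a saturated chain carbon bound to an aromatic carbon gives an at least 10-fold higher number from compound 3 to compound 4 (1.02 log units; beyond the scatter), so this small change is not neutral on the core of compound 3. The same kind of change on the core of compound 1, there on a saturated chain carbon bound to two aromatic carbons, cannot be read, because both of its ends are limits: the limit of > 30 mg/kg in this assay, at which 3 of the 4 values shown sit. Whether the effect carries from one core to the other is therefore not shown, and compound 4 gives only a limit, which leaves the full size of the step unknown.

Still open, as far as these compounds go, is how a propyl chain or an amine in the place of that methyl would read on the core of compound 3. Also open, from the compounds shown here alone, is whether any change on the core of compound 1 gives a number at all.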